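A few compounds are considered here, and "the series" means these few. Any claim that something is new, unique, unknown or untested is made for them only; others in the source may bear on it.

Working notes on the series in a toxicity assay on HeLa cells (Homo sapiens) for cytotoxicity; on this read-out lower numbers stand for higher toxicity in this test and higher numbers for lower toxicity in this test. Compound 1 `COc1nc(-c2ccsc2)ccc1[C@@H](c1ccccc1)[C@@](O)(CCN(C)C)c1cccc2ccccc12` gives only a limit in this assay: compound 1 gives > 64 ug/mL, which is a limit of the assay and not a number. Its standing is that of the limit of > 64 ug/mL in this assay, at which 1 of the 3 values shown sits. Compound 2 `COc1ncc(-c2ccccc2)cc1[C@@H](c1ccccc1)[C@@](O)(CCN(C)C)c1ccccc1` carries phenyl on the saturated chain carbon bound to an oxygen, and in this assay compound 2 gives 11.9 ug/mL. Compound 3 `COc1ncc(-c2ccccc2)cc1[C@@H](c1ccccc1)[C@@](O)(CCN(C)C)c1cccc2ccccc12` carries naphthalen-1-yl on that carbon, and in this assay compound 3 gives 30.4 ug/mL. Going by the values given here, the single measured step with one change, a 2.6-fold higher number from compound 2 to compound 3 (0.41 log units; beyond the scatter), concerns that saturated carbon and not the aryl group on the core. Compound 4 `COc1nc(-c2ccc(C#N)cc2)ccc1[C@@H](c1ccccc1)[C@@](O)(CCN(C)C)c1cccc2ccccc12` differs from compound 1 by 4-cyanophenyl in place of thiophen-3-yl on an aromatic carbon. Among the compounds with values here, no measured step touches this aryl group on the core, so the measured steps do not bear on the change; the naphthalen-1-yl of compound 1 is kept, and the value of compound 1 is a limit. Compound 4 is therefore expected to stay near the top of the measured range, with a step of an at least 1.1-fold lower number from compound 1 to compound 4 (0.06 log units; that floor lies within the scatter) expected from the limit. The estimate for compound 4 is 55 ug/mL, within 22 ug/mL to 130 ug/mL, with a fair chance that again only a limit is returned.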

Compound 4, half-maximal cytotoxic concentration: > 64 ug/mL
Compound 4: a limit, no number; the forecaster's own chance of this, stated with the estimate: 50%; middle value at least 1.1-fold (0.06 log units) from the limit.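

Going by these compounds alone, compound 1 and compound 4 each return only a limit of the assay, not a number, so no step between them can be read: the limit of > 64 ug/mL in this assay, at which 2 of the 4 values shown sit.
Going by these compounds, whether 4-cyanophenyl in place of thiophen-3-yl on an aromatic carbon changes the read-out at all remains open.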